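Diethylamino for dimethylamino on a cytotoxicity series

A few compounds are considered here, and "the series" means these few. Any claim that something is new, unique, unknown or untested is made for them only; others in the source may bear on it.

Measured compounds: compound 1 `CN(C)CCCn1c(N)c(-c2nc3ccccc3[nH]2)c2nc(C#N)c(C#N)nc21`, 8360 nM; compound 2 `CCN(CC)CCCn1c(N)c(-c2nc3ccccc3[nH]2)c2nc(C#N)c(C#N)nc21`, 7870 nM; compound 3 `CN(C)CCCCn1c(N)c(-c2nc3cc(Cl)ccc3[nH]2)c2nc(C#N)c(C#N)nc21`, 4730 nM.

In an ADME assay on HEK293 cells (Homo sapiens) for cytotoxicity, read by MTT assay, with a stated time of 48 h (a lower number here means a stronger inhibitor, a higher number a weaker inhibitor), compound 1 gives 8360 nM and compound 2 gives 7870 nM. The change between them is diethylamino in place of dimethylamino on a saturated chain carbon, three bonds along the chain from an aromatic nitrogen, and it made a 1.1-fold lower number from compound 1 to compound 2 (0.03 log units; within the scatter). Compound 3 gives 4730 nM in this assay; the difference between its core and the core of compound 1 is not broken down here. Compound 4 `CCN(CC)CCCCn1c(N)c(-c2nc3cc(Cl)ccc3[nH]2)c2nc(C#N)c(C#N)nc21` is not yet measured. It differs from compound 3 by diethylamino in place of dimethylamino on a saturated chain carbon, four bonds along the chain from an aromatic nitrogen, the same kind of change as from compound 1 to compound 2, except that the place lies four bonds along the chain from an aromatic nitrogen rather than three. Because compound 1 to compound 2 gave a 1.1-fold lower number from compound 1 to compound 2 (0.03 log units; within the scatter), the expected step for compound 4 in this assay is a 1.1-fold lower number from compound 3 to compound 4 (0.02 log units; within the scatter). Compound 4 is therefore estimated at 4500 nM, with a range from 2000 nM to 9500 nM.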

Compound 4, half-maximal inhibitory concentration: 3860 nM
Compound 4: middle estimate off by 1.2-fold (0.07 log units), on the high side; low and high end bracket the measured number.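

In this assay diethylamino in place of dimethylamino, four bonds along the chain from an aromatic nitrogen, gives a 1.2-fold lower number from compound 3 to compound 4 (0.09 log units; within the scatter) and so no change that can be told from the scatter. This does not show that the swap has any real effect on the number here, and two pairs set no rule for other cores in the series. What can be said is that the swap behaved alike on both cores, with neither step standing out from the other: the same change on two cores in this assay, a 1.1-fold lower number (0.03 log units; within the scatter) from compound 1 to compound 2 and a 1.2-fold lower number (0.09 log units; within the scatter) from compound 3 to compound 4, 1.2-fold (0.06 log units) apart, within the scatter of two such steps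

The compounds shown leave open whether a larger amine on the chain end, such as dipropylamino, would give a step beyond the scatter. They also leave open what a longer chain or a carboxylic acid in place of the amine would do.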